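Aryl exchange from compound 3 to compound 4

This account rests on a few compounds, and the source may have more. Where it says the series, first, only, none or still open, it means among the compounds named here.

In a functional assay on HeLa cells (Homo sapiens) for cytotoxicity, read by MTT assay, with a stated time of 72 h (a higher number here means a weaker inhibitor, a lower number a stronger inhibitor), compound 1 (`O=C(/C=C/c1ccc([N+](=O)[O-])cc1)Nc1cc2c(Nc3ccc(F)c(Cl)c3)ncnc2cc1O[C@H]1CCOC1`) gives 27400 nM while compound 2 (`COc1ccc(OC)c(/C=C/C(=O)Nc2cc3c(Nc4ccc(F)c(Cl)c4)ncnc3cc2O[C@H]2CCOC2)c1`) gives 26800 nM and compound 3 (`COc1cc(/C=C/C(=O)Nc2cc3c(Nc4ccc(F)c(Cl)c4)ncnc3cc2O[C@H]2CCOC2)cc(OC)c1O`) gives 27400 nM with the shared core held constant. Compound 3 is level with compound 1 at the digits shown, and compound 2 lies within the scatter of both.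

Compound 4 (`O=C(/C=C/c1ccc(F)cc1Cl)Nc1cc2c(Nc3ccc(F)c(Cl)c3)ncnc2cc1O[C@H]1CCOC1`) carries 2-chloro-4-fluorophenyl in place of 4-hydroxy-3,5-dimethoxyphenyl on a double-bonded chain carbon bound to a double-bonded chain carbon, and the exchange amounts to 2-chloro-4-fluorophenyl in place of 4-hydroxy-3,5-dimethoxyphenyl on a double-bonded chain carbon bound to a double-bonded chain carbon at that place.

All three measured steps change the group at this same place. They show no change at the digits printed from compound 1 to compound 3 (within the scatter) and a 1.0-fold higher number from compound 2 to compound 3 (0.01 log units; within the scatter) and also a 1.0-fold lower number from compound 1 to compound 2 (0.01 log units; within the scatter) as the full record so far. None of the three compounds carries a halogen on the group at this place, so the data do not test that kind of substituent directly.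

The expected step, estimated from these three flat steps, is a 1.1-fold lower number from compound 3 to compound 4 (0.06 log units; within the scatter) in this assay and amounts to no expected change beyond the scatter. Compound 4 is estimated at 24000 nM with an expected range from 12000 nM to 45000 nM pending measurement.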

Compound 4, half-maximal inhibitory concentration: 37500 nM
Compound 4: middle estimate off by 1.6-fold (0.19 log units), on the low side, within the range that was stated.
By their numbers in this assay, from the lowest: compounds 2, 1, 3 and 4 (each within the scatter of the next).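

Halogens on the group at this place are now tested for the first time: in this assay, 2-chloro-4-fluorophenyl gives a 1.4-fold higher number from compound 3 to compound 4 (0.14 log units; within the scatter), a 1.4-fold higher number from compound 2 to compound 4 (0.15 log units; within the scatter) and a 1.4-fold higher number from compound 1 to compound 4 (0.14 log units; within the scatter), so all three steps stay within the scatter. The flat record at this place therefore extends from 4-nitrophenyl, 2,5-dimethoxyphenyl and 4-hydroxy-3,5-dimethoxyphenyl to a group bearing chlorine and fluorine, and the exchange from compound 3 to compound 4, which goes from 1 hydrogen-bond donor and 3 hydrogen-bond acceptors to 0 of each, leaves no separation in this read-out. No supporting data on hand account for this flatness.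

As far as these compounds go, all four compounds carry a substituted phenyl at this place, so it remains open whether a dimethylamino group or a carboxylic acid in place of the phenyl would give a step beyond the scatter. Only this one place varies among the compounds shown, so the effect of changes elsewhere on the shared core also remains open.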